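This account rests on a few compounds, and the source may have more. Where it says the series, first, only, none or still open, it means among the compounds named here.

Measured compounds:
- compound 1 `CC1CCN(C2CCN(S(=O)(=O)c3ccc(F)cc3F)CC2)CC1` — in an ADME assay on HCT-116 cells (Homo sapiens) for cytotoxicity, read by CellTiter-Glo, with a stated time of 72 h (a higher number here means a weaker inhibitor, a lower number a stronger inhibitor), compound 1 gives > 5000 nM, a limit of the assay rather than a number.
- compound 2 `CC1CCCN(C2CCN(S(=O)(=O)c3ccc(OC(F)F)cc3)CC2)C1` — compound 2 gives > 5000 nM, again a limit.
- compound 3 `Cc1cc(C)c(S(=O)(=O)N2CCC(N3CCC(c4ccccc4)CC3)CC2)c(C)c1` — compound 3 gives > 5000 nM, also a limit.

Compound 1 therefore has no exact number of its own: it sits at the limit of > 5000 nM in this assay, at which 3 of the 3 values shown sit, and nothing separates it from the two other measured compounds, which share that same limit. Among the compounds with values here, no step between two measured compounds is available, so there is no measured change of this kind to lean on.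

The unmeasured compound 4 `CC1CCN(C2CCN(S(=O)(=O)c3cccc(N)c3)CC2)CC1` keeps the core of compound 1 and differs from it in one place: 3-aminophenyl in place of 2,4-difluorophenyl on a sulfonyl sulfur. Given that compound 1, compound 2 and compound 3 all rest at the limit, the expected step that the limit leaves unreadable from compound 1 to compound 4 is none beyond the usual scatter, and the result is expected to be reported once more as a limit. Compound 4 is expected to give 8000 nM. The expected range for compound 4 runs from 3000 nM to 30000 nM.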

Compound 4, half-maximal inhibitory concentration: > 5000 nM
Compound 4: a limit, no number (the forecaster's own chance of this, stated with the estimate: 85%); the middle value lies beyond the limit too.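

In this assay compound 4 gives > 5000 nM, a limit of the assay and not a number. Within the data shown here, no step from compound 1 to compound 4 can therefore be read: the limit of > 5000 nM in this assay, at which 4 of the 4 values shown sit. The compounds shown leave open what exact value any of them would have, and whether 3-aminophenyl in place of 2,4-difluorophenyl changes it.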